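The compounds below may be only part of what the source reports. "The series", "measured", "known", "first", "only" and "open" are said of these compounds alone.

Working notes on the series in a functional assay on the whole organism with Rattus norvegicus as the target, at a dose of 100 mg/kg; on this read-out higher numbers stand for more inhibition at the one dose given (going by the name of the read-out) and lower numbers for less inhibition. Three compounds carry the read-out so far. Compound 1 `CC/N=C(\S)NCCCCCn1nc(-c2ccccc2)ccc1=O` gives 66.4%. Compound 2 `N/C(S)=N/CCCCn1nc(-c2ccccc2)ccc1=O` gives 72%. Compound 3 `C/N=C(\S)NCCCCCCn1nc(-c2ccccc2)ccc1=O` gives 22.2%, the lowest of the three numbers: its nearest neighbour is compound 1, and compound 2 lies furthest from it.

The steps among the measured compounds: a number 5.6 percentage points higher from compound 1 to compound 2 (within the scatter), a change on a saturated chain carbon four bonds along the chain from an aromatic nitrogen; a number 44.2 percentage points lower from compound 1 to compound 3 (beyond the scatter), a change five bonds along the chain from an aromatic nitrogen; a number 49.8 percentage points lower from compound 2 to compound 3 (beyond the scatter), again four bonds along the chain from an aromatic nitrogen. Two of the three replacements in this region of the molecule moved the read-out by a large amount, one did not.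

Compound 4 `CN(C)/C(=N/CCCn1nc(-c2ccccc2)ccc1=O)NC#N` is not yet measured. Relative to compound 3 it carries a group of 8 heavy atoms (4 carbon, 4 nitrogen; no ring) in place of a group of 8 heavy atoms (5 carbon, 2 nitrogen, 1 sulfur; no ring), on a saturated chain carbon, three bonds along the chain from an aromatic nitrogen. The steps 1>3 and 2>3 show that a replacement of this kind can shift this assay by a large margin, so a large step is expected in either direction rather than none. Compound 3 sits at the bottom of the series, which leaves more room upward. Compound 4 is therefore estimated at 42%, within 12% to 72%, an expected step of a number 19.8 percentage points higher from compound 3 to compound 4 (beyond the scatter).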

Compound 4, a percentage reported as inhibition, in the whole organism at one dose (the size of the read-out at that dose, not a potency): 72.2%
Compound 4: middle estimate off by 30.2 percentage points, on the low side; the whole stated range lies below it.
By their numbers in this assay, from the lowest: compound 3; then compounds 1, 2 and 4 (each within the scatter of the next).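

In this assay, a sulfur-free group holding a nitrile, on a saturated chain carbon three bonds along the chain from an aromatic nitrogen, accompanies a number 50 percentage points higher from compound 3 to compound 4 (beyond the scatter), the first step upward from the bottom of the series. The sulfur-bearing groups give no separation from this one, with a number 0.2 percentage points higher from compound 2 to compound 4 (within the scatter) and a number 5.8 percentage points higher from compound 1 to compound 4 (within the scatter), both within the scatter, so among the compounds shown, sulfur in the group is not required for a number at this level, and compound 3 stands alone at the low end. No supporting measurement bears on why the numbers fall this way.

Chain length and terminal group change together in these steps, so the compounds shown do not separate the contribution of each to the low number of compound 3. Open questions are how the nitrile-bearing group behaves on a longer chain, and whether a urea or a simple amine at the chain end would fit with the higher numbers or with the low one.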